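The compounds below may be only part of what the source reports. "The series", "measured", "known", "first", "only" and "open" are said of these compounds alone.

Working notes on the series.

Compound 1 `CC(=O)O[C@@H]1C=CC(=O)O[C@@H]1[C@@H](COC(=O)c1ccc(Cl)cc1)OC(C)=O` gives 15700 nM in a functional assay on A549 cells (Homo sapiens) for antiproliferative activity, read by MTT assay, with a stated time of 6 days; on this read-out higher numbers stand for weaker inhibition and lower numbers for stronger inhibition. Compound 2 `O=C1C=C[C@@H](OCc2ccccc2)[C@@H]([C@@H](COC(=O)/C=C/c2ccccc2)OCc2ccccc2)O1` gives 13300 nM in this assay. Compound 3 `COc1ccc(/C=C/C(=O)OC[C@@H](OCc2ccccc2)[C@H]2OC(=O)C=C[C@H]2OCc2ccccc2)cc1` gives 4250 nM in this assay, the lowest of the three numbers; its nearest neighbour on this read-out is compound 2, and compound 1 lies furthest from it. Among the measured compounds shown here, the only single-point step among the measured compounds is a 3.1-fold lower number from compound 2 to compound 3 (0.50 log units; beyond the scatter), which is the sole step that bears on the change considered here.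

Compound 4 `O=C1C=C[C@@H](OCc2ccccc2)[C@@H]([C@@H](COC(=O)/C=C/c2ccc(F)cc2)OCc2ccccc2)O1` is not yet measured in this assay. It differs from compound 3 by fluoro in place of methoxy on an aromatic carbon. For the measured compounds named here, no measured pair shows fluoro against methoxy or fluoro against hydrogen at this position, so the expectation rests on the hydrogen-to-methoxy step alone. Since the methoxy gave the step of a 3.1-fold lower number from compound 2 to compound 3 (0.50 log units; beyond the scatter) and compound 4 no longer carries it, the expected number for compound 4 lies between those of compound 3 and compound 2, that is a modest step upward in this assay, as a 1.9-fold higher number from compound 3 to compound 4 (0.27 log units; within the scatter). Going by the values given here, compound 4 is therefore estimated at 8000 nM in this assay, with a range from 3000 nM to 25000 nM; the uncertainty is wide because a fluorine-bearing analogue has no precedent here.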

Compound 4, half-maximal inhibitory concentration: 12100 nM
The estimate for compound 4 lay 1.5-fold (0.18 log units) below the measured number, within the range that was stated.
By their numbers in this assay, from the lowest: compound 3; then compounds 4, 2 and 1 (each within the scatter of the next).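

At the aromatic carbon para to a large group, the series now has a second substituent to set against methoxy in this assay: fluoro in place of methoxy reverses most of the earlier drop in the number (a 2.8-fold higher number from compound 3 to compound 4 (0.45 log units; beyond the scatter)). Fluoro in place of hydrogen gives no change that can be read (a 1.1-fold lower number from compound 2 to compound 4 (0.04 log units; within the scatter)), so at this position the fluoro and hydrogen compounds cannot be told apart, and of the three cinnamate-type esters only the 4-methoxyphenyl compound, compound 3, stands apart from the other two. No measured data at hand bear on the reason for this difference between methoxy and fluoro.

The compounds shown leave open whether the lower number is particular to methoxy or would also appear with another group at this place, such as ethoxy, hydroxyl or dimethylamino. They also leave open whether the methoxy step would carry over if the benzyl ethers on the shared core were replaced by other groups, such as the acetates of compound 1.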